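A few compounds are considered here, and "the series" means these few. Any claim that something is new, unique, unknown or untested is made for them only; others in the source may bear on it.

Measured compounds:
compound 1 `Clc1ccc(-c2csc(N/N=C/c3cccs3)n2)cc1` – in a functional assay, read by spectrophotometry, with a stated time of 15 min, tested at 60 ug/mL (on this read-out higher numbers stand for a stronger effect at the one concentration tested and lower numbers for a weaker effect), compound 1 gives 85.2%
compound 2 `Fc1ccc(-c2csc(N/N=C/c3ccc(Cl)cc3Cl)n2)cc1` – in this assay compound 2 gives 92.4%

Among the compounds with values here, of the two numbers, compound 2 supplies the one with which the comparison begins; its nearest neighbour, compound 1, lies within the usual scatter of it, so the two values cannot be told apart. Within the data shown here, no step between measured compounds that differ in a single place has been recorded, so nothing about the effect of any one change is yet known.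

Compound 3 `Cc1ccc(-c2csc(N/N=C/c3ccc(Cl)cc3Cl)n2)cc1` is not yet measured. It differs from compound 2 by methyl in place of fluoro on an aromatic carbon – methyl in place of fluoro on an aromatic carbon, para to a large group, so that the 4-fluorophenyl becomes 4-methylphenyl.

Among the measured compounds shown here, no measured pair shows what this exchange does. The step from compound 2 to compound 3 in this assay is therefore expected to be small, a number 4.4 percentage points lower from compound 2 to compound 3 (within the scatter), in no particular direction and not beyond the scatter. For compound 3 the value is estimated at 88%, with a range from 70% to 98%.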

Compound 3, a percentage reported as inhibition, at one concentration (the size of the read-out at that concentration, not a potency): 83.2%
The estimate for compound 3 lay 4.8 percentage points above the measured number, within the range that was stated.
By their numbers in this assay, from the lowest: compounds 3, 1 and 2 (each within the scatter of the next).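

Within the data shown here, the exchange of fluoro for methyl on an aromatic carbon, para to a large group, provides the first step between compounds that differ in one place, and in this assay it reads a number 9.2 percentage points lower from compound 2 to compound 3 (within the scatter) and so does not separate the two compounds. At the one concentration tested, the 4-fluorophenyl and the 4-methylphenyl therefore cannot be told apart, something that compound 1 and compound 2, which differ in more than one place, could not show. No accompanying measurement accounts for this result.

Going by these compounds, whether an amine or a carboxylic acid in this place would give a step beyond the scatter remains open. Also open, on these data alone, is whether compound 2 and compound 3 would differ in the size of their effect at any other concentration: the read-out is a percentage at one concentration only.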